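The compounds below may be only part of what the source reports. "The series", "measured", "known", "first", "only" and "open" are said of these compounds alone.

Of the compounds shown here, three built on the same core have been measured in a functional assay on A549 cells (Homo sapiens) for cytotoxicity, read by sulforhodamine B assay, with a stated time of 48 h, tested at 100 uM; on this read-out higher numbers stand for a weaker effect at the one concentration tested and lower numbers for a stronger effect. Compound 1 `COc1ccc(-c2cc(/C=C/C(=O)c3ccc(N)cc3)[nH]n2)cc1` gives -75%, compound 2 `COc1cc(-c2cc(/C=C/C(=O)c3ccc(N)cc3)[nH]n2)cc(OC)c1OC` gives -52%, and compound 3 `COc1ccc(C(=O)/C=C/c2cc(-c3cc(OC)c(OC)c(OC)c3)n[nH]2)cc1OC` gives -78%. Compound 2 thus stands highest of the three, the weakest effect on this read-out, with compound 1 nearest and compound 3 furthest. For the measured compounds named here, the one step measured at a single place is a number 26 percentage points lower from compound 2 to compound 3 (beyond the scatter), which changes the group on the carbonyl carbon, so it does not bear directly on compound 4 `COc1ccc(-c2cc(/C=C/C(=O)c3ccc(N)cc3)[nH]n2)cc1OC`. Compound 4 differs from compound 2 by hydrogen in place of methoxy on an aromatic carbon. Compounds 1 and 2 differ at two places, so their values only show that fewer methoxy groups went with a lower number. The expected step is therefore a number 11 percentage points lower from compound 2 to compound 4 (beyond the scatter), a modest drop toward compound 1. Compound 4 is expected to give about -63%, within -80% to -46%.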

Compound 4, a percentage reported as activity, at one concentration (the size of the read-out at that concentration, not a potency): -76%
Beside the measured number, compound 4's estimate is 13 percentage points above it; low and high end bracket the measured number.
By their numbers in this assay, from the lowest: compounds 3, 4 and 1 (each within the scatter of the next); then compound 2.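

In this assay, replacing this one methoxy with hydrogen gives a number 24 percentage points lower from compound 2 to compound 4 (beyond the scatter), so a single group on this aromatic carbon is enough to set compound 2 apart. The other methoxy step, a number 1 percentage points lower from compound 1 to compound 4 (within the scatter), leaves compound 1 and compound 4 indistinguishable, so adding a methoxy to this ring does not always shift the number. Nothing measured here explains this difference. On these data alone, whether a hydroxyl group or a fluorine atom at this position would behave like hydrogen or like methoxy remains open.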